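A few compounds are considered here, and "the series" means these few. Any claim that something is new, unique, unknown or untested is made for them only; others in the source may bear on it.

Compound 1 `Nc1ncnc2c1ncn2C[C@@H]1C[C@H](O)c2ccccc21` and compound 2 `O[C@H]1C[C@@H](Cn2cnc3c(Cl)ncnc32)c2ccccc21` share one core; compound 3 `COC1=C(OC)C(O)(CCn2cnc3c(N)ncnc32)OC1=O` and compound 4 `COC1=C(OC)C(O)(CCn2cnc3c(Cl)ncnc32)OC1=O` share another, and the difference between the two cores is not broken down here. In an ADME assay on L1210/0 cells (Mus musculus) for cytotoxicity, with a stated time of 48 h (on this read-out lower numbers stand for stronger inhibition and higher numbers for weaker inhibition), compound 1 gives only a limit, > 200000 nM. Compound 2 also gives only a limit in this assay, > 200000 nM. The change chloro in place of amino on an aromatic carbon therefore yields a step that the two limits leave unreadable from compound 1 to compound 2. Compound 3 likewise gives only a limit in this assay, > 200000 nM. Compound 4 carries the same change, (chloro in place of amino on an aromatic carbon). The expected step of a number no higher from compound 3 to compound 4 (the limit leaves the size open) in this assay is taken as flat, because the limit of > 200000 nM in this assay, at which 3 of the 3 values shown sit, leaves no measured effect of this change to carry over. Compound 4 is thus expected to sit at 200000 nM in this assay, most probably again as a limit rather than a number.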

Compound 4, half-maximal inhibitory concentration: > 200000 nM
Compound 4: a limit, no number (the forecaster's own chance of this, stated with the estimate: 85%); the middle value sits exactly at the limit.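

No new step can be read: compound 3 and compound 4 both give only limits in this assay. The size of the chloro in place of amino change, and any difference between the two cores, stays open: the limit of > 200000 nM in this assay, at which 4 of the 4 values shown sit.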